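A few compounds are considered here, and "the series" means these few. Any claim that something is new, unique, unknown or untested is made for them only; others in the source may bear on it.

Measured compounds:
compound 1 `COc1cc(C(=O)c2sc(-c3ccc(Cl)cc3)cc2N)cc(OC)c1OC`: 93 nM
compound 2 `COc1cc(C(=O)c2sc(-c3ccccc3Cl)cc2N)cc(OC)c1OC`: 20 nM

Among the compounds with values here, compound 2 holds the lowest number of the two in a functional assay on L1210 cells (Mus musculus) for antiproliferative activity; a lower number here means a stronger inhibitor, a higher number a weaker inhibitor; its only neighbour is compound 1, and the step between them is a 4.7-fold lower number from compound 1 to compound 2 (0.67 log units; beyond the scatter). Compound 3 `COc1cccc(-c2cc(N)c(C(=O)c3cc(OC)c(OC)c(OC)c3)s2)c1` has not yet been measured. It differs from compound 2 by 3-methoxyphenyl in place of 2-chlorophenyl on an aromatic carbon. Within the data shown here, the one measured step shows that shifting the chlorine within the phenyl ring moves this assay beyond the scatter, so a change of the same ring is likely to matter. Among the measured compounds shown here, no measured compound carries a methoxyphenyl of any kind, so the direction must be taken as open; the 4-chlorophenyl result of compound 1 suggests that leaving the 2-chlorophenyl arrangement tends to raise the number. Compound 3 is expected to give 60 nM, in the range 15 nM to 250 nM. The expected step is a 3.0-fold higher number from compound 2 to compound 3 (0.48 log units; beyond the scatter).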

Compound 3, half-maximal inhibitory concentration: 22 nM
Beside the measured number, compound 3's estimate is 2.7-fold (0.44 log units) above it; measured number inside the range.
By their numbers in this assay, from the lowest: compounds 2 and 3 (each within the scatter of the next); then compound 1.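

At this aromatic carbon next to the ring sulfur, this assay shows a 1.1-fold higher number from compound 2 to compound 3 (0.04 log units; within the scatter) and does not separate 3-methoxyphenyl from 2-chlorophenyl, so the low number is not confined to the 2-chlorophenyl. With a 4.2-fold lower number from compound 1 to compound 3 (0.63 log units; beyond the scatter) as the second step, the 4-chlorophenyl of compound 1 now stands apart from two other substituted phenyl groups, not just one. Among these three compounds, the substituent and its ring position can therefore both change with no readable shift, and compound 1 is the exception.

Nothing available explains these differences. As far as these compounds go, since substituent and ring position change together between compound 2 and compound 3, neither can be read alone, and where 4-methoxyphenyl, 3-chlorophenyl or an aminophenyl group would fall stays open.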